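The compounds below may be only part of what the source reports. "The series", "measured", "known", "first", "only" and "open" are said of these compounds alone.

Three compounds share one core and differ only in the group on the amide-type nitrogen. Compound 1 `O=C(CCc1cccc2c1B(O)OC2)Nc1nccs1` carries a 1,3-thiazol-2-yl group there; in a functional assay on HCT-116 cells (Homo sapiens) for antiproliferative activity, read by MTT assay, with a stated time of 72 h (on this read-out higher numbers stand for weaker inhibition and lower numbers for stronger inhibition), compound 1 gives > 100000 nM, which is a limit of the assay and not a number, and so it sits at the limit of > 100000 nM in this assay, at which 1 of the 3 values shown sits. Compound 2 `O=C(CCc1cccc2c1B(O)OC2)Nc1ccc(Br)cc1` carries a 4-bromophenyl group, and in this assay compound 2 gives 46000 nM. Compound 3 `O=C(CCc1cccc2c1B(O)OC2)Nc1cccc(Br)c1` carries a 3-bromophenyl group, and in this assay compound 3 gives 1400 nM, the lowest of the two numbers. The step of a 33-fold lower number from compound 2 to compound 3 (1.52 log units; beyond the scatter) is large, as is an at least 71-fold lower number from compound 1 to compound 3 (1.85 log units; beyond the scatter), while an at least 2.1-fold lower number from compound 1 to compound 2 (0.33 log units; beyond the scatter) is at least modest.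

Compound 4 `CC(=O)c1cccc(-c2cccc(NC(=O)CCc3cccc4c3B(O)OC4)c2)c1` keeps everything of compound 3 except one change: 3-acetylphenyl in place of bromo on an aromatic carbon. Within the data shown here, no measured step replaces a bromo with another group at the same spot; the measured steps show only that where the bromo sits matters greatly, as in a 33-fold lower number from compound 2 to compound 3 (1.52 log units; beyond the scatter). The expectation therefore rests on thin ground, and the nearest guide is compound 3 with its 1400 nM. The expected step is a 1.1-fold higher number from compound 3 to compound 4 (0.03 log units; within the scatter), within the scatter. Compound 4 is estimated at 1500 nM, between 300 nM and 8000 nM.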

Compound 4, half-maximal inhibitory concentration: 86 nM
For compound 4 the middle estimate is 17-fold (1.24 log units) above the measured one, outside the stated range (below it).
By their numbers in this assay, from the lowest: compound 4; then compound 3; then compound 2. At a limit, above all of these: compound 1.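

In this assay, the step from a single bromo to 3-acetylphenyl gives a 16-fold lower number from compound 3 to compound 4 (1.21 log units; beyond the scatter), a large change that lies beyond the usual scatter. Among these compounds, the earlier compounds showed only that the number depends on where the bromo sits and on which group is carried by the amide-type nitrogen; they gave no sign of how much could be built out from this spot on the ring. Compound 4 shows that this spot, meta to a large group, can carry 9 heavy atoms, including a second six-membered aromatic ring and a carbonyl, in place of one bromine, and that the number falls sharply, yet nothing shown here explains the drop or tells whether the added ring or the acetyl group accounts for it.

A plain phenyl group, or a phenyl group carrying an amine or a carboxylic acid where compound 4 has its acetyl group, would help separate the part played by the ring from that of the acetyl group. Also open, going by these compounds, is whether the same gain would appear with 3-acetylphenyl at another place on the ring that carries the bromo in compound 2.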